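Chloro placement on the pyridylmethoxy ring of compound 2

The compounds below may be only part of what the source reports. "The series", "measured", "known", "first", "only" and "open" are said of these compounds alone.

Measured compounds:
Compound 1 `Cc1ccc(-c2cc3n(n2)CCCC3)nc1`: in a functional assay on HEK293 cells for negative allosteric modulation of metabotropic glutamate receptor 5 (Rattus norvegicus), read by FLIPR and calcium flux, with a stated time of 170 s (a higher number here means a weaker inhibitor, a lower number a stronger inhibitor), compound 1 gives 3000 nM.
Compound 2 `c1ccc(COc2cc3n(n2)CCCC3)nc1`: compound 2 gives 2500 nM.
Compound 3 `Clc1ccnc(COc2cc3n(n2)CCCC3)c1`: compound 3 gives only a limit, > 10000 nM.

Compound 2 holds the lowest of the two numbers in this assay; compound 1 sits close to it, and the gap between the two is within the scatter, so no order between them can be stated. Compound 4 `Clc1ccc(COc2cc3n(n2)CCCC3)nc1` has not been measured. It differs from compound 2 by chloro in place of hydrogen on an aromatic carbon.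

For the measured compounds named here, one measured step bears on this change: an at least 4.0-fold higher number from compound 2 to compound 3 (0.60 log units; beyond the scatter). Going by these compounds, in that step the chloro enters the same ring as in compound 4 but on a different aromatic carbon, and the value of compound 3 is a limit (the limit of > 10000 nM in this assay, at which 1 of the 3 values shown sits), so the true size of that step is unknown beyond its minimum. The precedent is single and concerns another carbon, so it is taken as a direction rather than a size.

For compound 4 the expected step is a 2.8-fold higher number from compound 2 to compound 4 (0.45 log units; beyond the scatter), a weakening beyond the scatter. Compound 4 is therefore estimated at 7000 nM, within 2500 nM to 20000 nM, with a real chance that this assay reports only a limit.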

Compound 4, half-maximal inhibitory concentration: 1550 nM
Compound 4: the middle estimate sits 4.5-fold (0.65 log units) above what was measured; measured number outside the range, below it.
By their numbers in this assay, from the lowest: compounds 4, 2 and 1 (each within the scatter of the next). At a limit, above all of these: compound 3.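

In this assay, chloro in place of hydrogen on an aromatic carbon two atoms from the ring nitrogen and para to a large group is tolerated: the step is a 1.6-fold lower number from compound 2 to compound 4 (0.21 log units; within the scatter). For the compounds shown here, the only earlier chloro step, an at least 4.0-fold higher number from compound 2 to compound 3 (0.60 log units; beyond the scatter), could have meant that chloro on this ring is poorly accepted wherever it sits, but the new step shows that the loss does not hold at every aromatic carbon of the ring, so the outcome depends on where the chloro stands. Compound 3 gives only a limit, > 10000 nM, so the step to it has no known size and the difference between the two placements stays unsized: the limit of > 10000 nM in this assay, at which 1 of the 4 values shown sits.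

The new step lies within the scatter. Chloro at this carbon counts as neither a gain nor a loss, and it remains open whether fluoro, nitrile or methoxy at the same carbon would move the number beyond the scatter in either direction. Going by these compounds, the effect of chloro on the remaining carbons of the ring is also open, as is whether a larger group such as trifluoromethyl fits at this position.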